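Swapping an Aryl Amide for a Cyclopropyl Amide

The source may hold more compounds than are shown below. What is called first, only, known or untested is meant among the compounds shown, and "the series" means these compounds.

Three compounds share one core and differ only in the group attached to an amide nitrogen. Compound 1 `CN1C[C@H](C(=O)Nc2ccc(C(F)(F)F)cc2)[C@@H](c2ccc(/C=C/C(=O)Nc3ccccc3N)cc2)C1` carries a 4-(trifluoromethyl)phenyl there; in an in vitro ADME assay on microsomes from liver (Homo sapiens) for pharmacokinetics, read by LC-MS, with a stated time of 10 min, tested at 1 uM (a higher number here means faster removal of the compound, a lower number slower removal), compound 1 gives 6 mL/min/kg. Compound 2 `CN1C[C@H](C(=O)Nc2ccc(Br)cc2)[C@@H](c2ccc(/C=C/C(=O)Nc3ccccc3N)cc2)C1` carries a 4-bromophenyl instead, and in this assay compound 2 gives 3 mL/min/kg. Compound 3 `Cc1cc(NC(=O)[C@H]2CN(C)C[C@@H]2c2ccc(/C=C/C(=O)Nc3ccccc3N)cc2)ccc1Cl` carries a 4-chloro-3-methylphenyl, and in this assay compound 3 gives 15 mL/min/kg. Among these three numbers compound 1 stands second highest: the step of a 2.0-fold lower number from compound 1 to compound 2 (0.30 log units; within the scatter) is within the scatter, while the step of a 2.5-fold higher number from compound 1 to compound 3 (0.40 log units; beyond the scatter) is beyond it, as is the step of a 5.0-fold higher number from compound 2 to compound 3 (0.70 log units; beyond the scatter).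

Compound 4 `CN1C[C@H](C(=O)NC2CC2)[C@@H](c2ccc(/C=C/C(=O)Nc3ccccc3N)cc2)C1` takes a different route. The change from compound 1 is cyclopropyl in place of 4-(trifluoromethyl)phenyl on an amide-type nitrogen. Among the measured compounds shown here, none of the measured steps exchanges an aromatic ring for a cyclopropyl, so none bears directly on this step; they show only that varying the substituents on the aromatic ring moves the number by modest amounts. For the measured compounds named here, with nothing pointing to a large move, compound 4 is expected to give about 4 mL/min/kg, within a range of 1.5 mL/min/kg to 10 mL/min/kg, which means an expected step of a 1.5-fold lower number from compound 1 to compound 4 (0.18 log units; within the scatter), that is, no step clearly beyond the scatter.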

Compound 4, clearance: 10 mL/min/kg
Beside the measured number, compound 4's estimate is 2.5-fold (0.40 log units) below it, within the range that was stated.
By their numbers in this assay, from the lowest: compounds 2, 1, 4 and 3 (each within the scatter of the next, the first and the last beyond it).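

Until now the amide-type nitrogen had carried only substituted phenyl groups, and compound 4 shows that the ring can be exchanged for something much smaller, with cyclopropyl in place of 4-(trifluoromethyl)phenyl. In this assay this exchange gives a 1.7-fold higher number from compound 1 to compound 4 (0.22 log units; within the scatter) and a 1.5-fold lower number from compound 3 to compound 4 (0.18 log units; within the scatter), so neither of these two aryl groups is clearly separated from cyclopropyl, and only the comparison with 4-bromophenyl stands out, at a 3.3-fold higher number from compound 2 to compound 4 (0.52 log units; beyond the scatter). Nothing available here gives a reason for these numbers.

What the compounds shown leave open is how a larger non-aromatic ring such as cyclohexyl, a longer chain such as n-butyl, or a group carrying an amine or a carboxylic acid would read on this same nitrogen. Among the compounds shown here, with cyclopropyl as the only non-aromatic group here, the result for compound 4 also cannot be extended to non-aromatic groups in general.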